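Swapping the Amine Terminus on a Flavone Side Chain

This account rests on a few compounds, and the source may have more. Where it says the series, first, only, none or still open, it means among the compounds named here.

The measured compounds:
Compound 1, `O=c1cc(-c2ccccc2)oc2cc(O)c(OCCCN3CCCC3)c(O)c12`, which in a functional assay on BCG823 cells (Homo sapiens) for antiproliferative activity, read by MTT assay, with a stated time of 48 h (a lower number here means a stronger inhibitor, a higher number a weaker inhibitor), gives only a limit, > 100000 nM.
Compound 2, `COc1cc2oc(-c3ccccc3)cc(=O)c2c(O)c1OCCCN1CCN(C)CC1`, which in this assay gives 31300 nM.
Compound 3, `CN1CCN(CCCOc2c(OCc3ccccc3)cc3oc(-c4ccccc4)cc(=O)c3c2O)CC1`, which in this assay gives 4100 nM.

Among the two numbers available, compound 2 stands highest, meaning it is the weaker of the two inhibitors. Its nearest neighbour is compound 3, reached by a 7.6-fold lower number from compound 2 to compound 3 (0.88 log units; beyond the scatter). Compound 1 sits at the assay limit, (the limit of > 100000 nM in this assay, at which 1 of the 3 values shown sits), so it provides a bound rather than a number.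

Compound 4, `CCN(CC)CCCOc1c(OC)cc2oc(-c3ccccc3)cc(=O)c2c1O`, has not yet been measured. It differs from compound 2 by diethylamino in place of 4-methylpiperazin-1-yl on a saturated chain carbon, three bonds along the chain from an oxygen on an aromatic ring. Within the data shown here, no measured step touches this place: the only known step, from compound 2 to compound 3, alters a chain carbon bound to an oxygen on the aromatic ring, not the amine at the far end of the propyl chain. There is therefore no basis for expecting a shift beyond the usual scatter in this assay in either direction.

Compound 4 is thus estimated at 25000 nM, within 8000 nM to 80000 nM. The expected step is a 1.3-fold lower number from compound 2 to compound 4 (0.10 log units; within the scatter).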

Compound 4, half-maximal inhibitory concentration: 5700 nM
Compound 4: the middle estimate sits 4.4-fold (0.64 log units) above what was measured; measured number outside the range, below it.
By their numbers in this assay, from the lowest: compounds 3 and 4 (each within the scatter of the next); then compound 2. At a limit, above all of these: compound 1.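

The place three bonds along the chain from an oxygen on an aromatic ring turns out to matter in this assay: putting diethylamino in place of 4-methylpiperazin-1-yl gives a 5.5-fold lower number from compound 2 to compound 4 (0.74 log units; beyond the scatter). The earlier step had changed only a saturated chain carbon bound to an oxygen on an aromatic ring, so the amine group at this other place now has a measured step of its own, and it too lies beyond the scatter. The entering group has no ring and fewer heavy atoms than the one it replaces, with one nitrogen instead of two, but nothing available here explains why the number changes.

As far as these compounds go, this single swap alters the ring and the nitrogen count together, so it remains open which of the two goes with the lower number; a piperidin-1-yl group, which keeps a six-membered ring with a single nitrogen, would separate them. Also open, from the compounds shown here alone, is whether the same holds for a smaller amine such as dimethylamino, or for diethylamino carried on a longer chain such as butyl.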